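Lengthening the diamine chain by one carbon

The compounds below may be only part of what the source reports. "The series", "measured", "known", "first", "only" and "open" are said of these compounds alone.

Compound 2 `NCC(N)CC(=O)N1CCN(C(=O)CCn2cccc(O)c2=O)CC1` and compound 1 `CC(C)(C)OC(=O)NCC(CCCCNC(=O)CCn1cccc(O)c1=O)NC(=O)OC(C)(C)C` share a core and differ in their outer parts. In a physicochemical assay, read by spectrophotometry, with a stated time of 10 min, tested at 0.02 mM, in the presence of a further agent that is not named here (a higher number here means a stronger effect of the compound at the concentration tested, a lower number a weaker effect), compound 1 gives 11.1%, and compound 2 gives 10.3%, which is the lower of the two numbers but within the scatter of the other. Compound 3 `NCC(N)CCC(=O)N1CCN(C(=O)CCn2cccc(O)c2=O)CC1` carries 2,3-diaminopropyl in place of 1,2-diaminoethyl on a saturated chain carbon bound to a carbonyl carbon. Going by the values given here, no step between measured compounds is known here, so the change is expected to stay within the scatter, with the step of a number 0.7 percentage points higher from compound 2 to compound 3 (within the scatter) estimated as small and without clear direction. Compound 3 is therefore expected to give 11%, likely between 3% and 20%.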

Compound 3, a percentage reported as activity, at one concentration (the size of the read-out at that concentration, not a potency): 11.8%
Compound 3: middle estimate off by 0.8 percentage points, on the low side; the measured number falls inside the stated range.
By their numbers in this assay, from the lowest: compounds 2, 1 and 3 (each within the scatter of the next).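

In this assay, the step of a number 1.5 percentage points higher from compound 2 to compound 3 (within the scatter) comes with 2,3-diaminopropyl in place of 1,2-diaminoethyl on a saturated chain carbon bound to a carbonyl carbon. Going by these compounds alone, this is the first comparison of compounds that differ in one place, and it shows that this one-carbon change leaves the read-out within the usual scatter. No measurement here offers an explanation for this result. Still open, from the compounds shown here alone, is whether 3,4-diaminobutyl, a longer chain, or a carboxylic acid in place of the diamine would give a clearly different read-out.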